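A few compounds are considered here, and "the series" means these few. Any claim that something is new, unique, unknown or untested is made for them only; others in the source may bear on it.

Compound 1 `COc1ccc(-c2csc(NC(=O)COc3ccc(C(=O)c4ccc(C)cc4)cc3C)n2)cc1` and compound 2 `Cc1cc(C(=O)c2cccc(Br)c2)ccc1OCC(=O)Nc1nc(-c2ccccc2)cs1` share a core and were both tested in a functional assay on DLA cells (Mus musculus) for cytotoxicity, read by trypan blue exclusion, with a stated time of 48 h; a higher number here means a weaker inhibitor, a lower number a stronger inhibitor. In this assay compound 1 gives 16000 nM. In this assay compound 2 gives 21700 nM, the higher of the two numbers, though its gap to compound 1 lies within the scatter, so the two values show no order between them. Compound 3 `COc1ccc(-c2csc(NC(=O)COc3ccc(C(=O)c4cccc(Br)c4)cc3C)n2)cc1` has not yet been measured. It differs from compound 2 in one place: methoxy in place of hydrogen on an aromatic carbon, on an aromatic carbon of a six-membered aromatic ring of carbon only, para to a large group. Cut one bond further out, the change reads as phenyl to 4-methoxyphenyl. Among the measured compounds shown here, no step between measured compounds isolates this change. Compound 1 carries the same methoxy group but also differs from compound 2 elsewhere, and its value sits within the scatter of compound 2, which gives no sign of a large effect. The step expected here is a 1.3-fold lower number from compound 2 to compound 3 (0.11 log units; within the scatter), in no direction beyond the scatter. Compound 3 is therefore expected to give 17000 nM, with a range from 8000 nM to 40000 nM.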

Compound 3, half-maximal inhibitory concentration: 35400 nM
For compound 3 the middle estimate is 2.1-fold (0.32 log units) below the measured one; the measured number falls inside the stated range.
By their numbers in this assay, from the lowest: compounds 1, 2 and 3 (each within the scatter of the next, the first and the last beyond it).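

In this assay, the phenyl to 4-methoxyphenyl change can now be read on its own, and methoxy in place of hydrogen on this aromatic carbon, para to a large group, gives a 1.6-fold higher number from compound 2 to compound 3 (0.21 log units; within the scatter), so this pair shows no change that the assay can resolve. Compound 3 also makes a second single-place comparison possible: with the 4-methoxyphenyl group held constant, 3-bromophenyl in place of 4-methylphenyl on a carbonyl carbon gives a 2.2-fold higher number from compound 1 to compound 3 (0.34 log units; beyond the scatter), a modest step and the only one of the two beyond the scatter. Nothing available on these compounds bears on the reason for either step.

On these data alone, the step on the carbonyl carbon rests on a single pair carrying the 4-methoxyphenyl group, so whether the same replacement would give a similar step with a plain phenyl group in that place remains open. The compounds shown also leave open how this para position would respond to an amine, a carboxylic acid or a longer alkoxy chain in place of methoxy.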